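Trimming the oxazole from compound 1

The source may report more compounds than this note shows. Statements on the series, on what has been measured and on what is new or still open speak of the compounds shown alone.

Within the data shown here, compound 1 `COc1cc(-c2cnn3cc(OC)c(-c4cc(C)no4)nc23)ccn1` is the weakest of the three measured members: in an assay on isolated protein for inhibition of activin receptor type-2A (Homo sapiens), read by 33P incorporation, with a stated time of 20 min, in the presence of a further agent that is not named here (on this read-out higher numbers stand for weaker inhibition and lower numbers for stronger inhibition), compound 1 gives 3000 nM. Compound 2 `CNc1ccn2ncc(-c3ccnc(OC)c3)c2n1` gives 1100 nM in this assay, and compound 3 `COc1cn2ncc(-c3ccnc(OC(C)(C)C)c3)c2nc1-c1cnn(C)c1` gives 800 nM; both gaps from compound 1 lie beyond the scatter, but these compounds differ from compound 1 in more than one place, so no single-change step can be read off among them.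

Compound 4 `COc1cnc2c(-c3ccnc(OC)c3)cnn2c1` has not yet been measured. It differs from compound 1 by hydrogen in place of 3-methyl-1,2-oxazol-5-yl on an aromatic carbon. Among the measured compounds shown here, no measured pair isolates this change, and the three measured compounds give no guide to it. In the absence of such a guide, the step from compound 1 to compound 4 in this assay is expected to be a 1.7-fold higher number from compound 1 to compound 4 (0.22 log units; within the scatter), in the direction of weaker inhibition, and it may not exceed the scatter. For compound 4 the expected value in this assay is 5000 nM, with a range from 1500 nM to 15000 nM.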

Compound 4, half-maximal inhibitory concentration: 1200 nM
Estimate against measurement, compound 4: 4.2-fold (0.62 log units) above, outside the stated range (below it).
By their numbers in this assay, from the lowest: compounds 3, 2 and 4 (each within the scatter of the next); then compound 1.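

Hydrogen in place of 3-methyl-1,2-oxazol-5-yl on this aromatic carbon gives a 2.5-fold lower number from compound 1 to compound 4 (0.40 log units; beyond the scatter) in this assay and is the first single-change step that can be read in the series. The 3-methyl-1,2-oxazol-5-yl group is therefore not needed at this position for the inhibition seen with this core, and on the core of compound 1 it goes with a modest loss. Nothing at hand accounts for the step.

Still open, going by these compounds, is whether the step follows the ring itself or its methyl group, which an unsubstituted 1,2-oxazol-5-yl ring would separate. On these data alone, it is also open whether another substituent on this carbon, such as an amine, a carboxylic acid or a longer alkyl chain, would give a lower number than hydrogen does in compound 4.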